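The source may report more compounds than this note shows. Statements on the series, on what has been measured and on what is new or still open speak of the compounds shown alone.

Working notes on the hydrazone series.

Among the compounds with values here, compound 2 `Cc1nc(N(C)C(=O)NC(=O)c2c(F)cccc2F)sc1C(=O)N/N=C/c1cccc(C(F)(F)F)c1` gives 30.3 ug/mL in a functional assay on A549 cells (Homo sapiens) for inhibition, read by MTT assay, with a stated time of 72 h (a lower number here means a stronger inhibitor, a higher number a weaker inhibitor), the highest of the three numbers measured so far. Within the data shown here, compound 1 `CN(C(=O)NC(=O)c1c(F)cccc1F)c1nc(C(F)(F)F)c(C(=O)N/N=C/c2cccc(C(F)(F)F)c2)s1` gives 27.6 ug/mL in this assay, and the single step of a 1.1-fold higher number from compound 1 to compound 2 (0.04 log units; within the scatter) is within the scatter, so these two stand together. Among the measured compounds shown here, compound 3 `CN(C(=O)NC(=O)c1ccc(C(F)(F)F)cc1)c1nc(C(F)(F)F)c(C(=O)N/N=C/c2cc(C(F)(F)F)cc(C(F)(F)F)c2)s1` gives 5.9 ug/mL in this assay, a lower number than compound 2 beyond the scatter, but compound 3 differs from compound 2 in more than one place, so no single step connects them.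

Compound 4 `Cc1nc(N(C)C(=O)NC(=O)c2c(F)cccc2F)sc1C(=O)N/N=C/c1cc(C(F)(F)F)cc(C(F)(F)F)c1` differs from compound 2 by one change: trifluoromethyl in place of hydrogen on an aromatic carbon. For the measured compounds named here, no measured step isolates this change. Going by the values given here, the one measured step, from compound 1 to compound 2, concerns a different position and was within the scatter, so it says nothing about the present change. Among the compounds with values here, the only hint comes from compound 3, which carries the same pair of trifluoromethyl groups on that ring and gives a lower number than compound 2, though other differences share in that gap.

On that basis a lower number than compound 2 is expected for compound 4, with a step estimated at a 2.0-fold lower number from compound 2 to compound 4 (0.31 log units; beyond the scatter), but with wide uncertainty. The estimate for compound 4 in this assay is 15 ug/mL, ranging from 6 ug/mL to 40 ug/mL.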

Compound 4, half-maximal inhibitory concentration: 13 ug/mL
Beside the measured number, compound 4's estimate is 1.2-fold (0.06 log units) above it; low and high end bracket the measured number.
By their numbers in this assay, from the lowest: compound 3; then compound 4; then compounds 1 and 2 (each within the scatter of the next).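

Within the data shown here, compound 4 gives the first single-place reading of this change: trifluoromethyl in place of hydrogen on an aromatic carbon, meta to a large group and meta to a trifluoromethyl group, produces a 2.3-fold lower number from compound 2 to compound 4 (0.37 log units; beyond the scatter) in this assay. Among these compounds, this step is modest but beyond the scatter, so the ring carrying the hydrazone can move the number on its own, whereas the only earlier single-place step, a 1.1-fold higher number from compound 1 to compound 2 (0.04 log units; within the scatter), concerned another position and showed no such shift; compound 3 differs from compound 4 in more than one place, so no step can be read between them. No measurement in hand speaks to the cause of the step.

The compounds shown leave open whether an amine, a carboxylic acid or a methoxy group on the same aromatic carbon would move the number in the same direction as trifluoromethyl does. They also leave open whether the same change would give a step of similar size on the core of compound 1, which carries trifluoromethyl in place of methyl.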